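Thiosemicarbazones on HT-29 cells: a single aryl change

A few compounds are considered here, and "the series" means these few. Any claim that something is new, unique, unknown or untested is made for them only; others in the source may bear on it.

Compound 1 `N#Cc1ccc(NC(=S)N/N=C/c2ccc3ccccc3n2)cc1`: 15600 nM
Compound 2 `FC(F)(F)c1ccccc1NC(=S)N/N=C/c1ccc2ccccc2n1`: 18100 nM
Compound 3 `Fc1ccc(NC(=S)N/N=C/c2ccc3ccccc3n2)cc1`: 28500 nM

Of the compounds shown here, three sharing one core have been measured in a functional assay on HT-29 cells (Homo sapiens) for antiproliferative activity, read by sulforhodamine B assay, with a stated time of 72 h; on this read-out higher numbers stand for weaker inhibition and lower numbers for stronger inhibition. Compound 3 gives the highest of the three numbers, but it sits within the scatter of both compound 2 and compound 1, so no order among them can be read from these values.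

Compound 4 `COc1ccccc1NC(=S)N/N=C/c1ccc2ccccc2n1` has not yet been measured. It differs from compound 3 in one place: 2-methoxyphenyl in place of 4-fluorophenyl on an amide-type nitrogen.

Within the data shown here, the only measured step that bears on this change is a 1.8-fold higher number from compound 1 to compound 3 (0.26 log units; within the scatter), a change on the same aryl substituent that left the read-out essentially where it was. Compound 2 carries its trifluoromethyl group on that same aryl ring and gives a number within the scatter of compound 3. Nothing measured here separates one aryl substituent from another beyond the scatter, and the 2-methoxyphenyl group introduces only one hydrogen-bond acceptor. Compound 4 is therefore expected to show no step beyond the scatter, a 1.3-fold lower number from compound 3 to compound 4 (0.11 log units; within the scatter). The estimate for compound 4 in this assay is 22000 nM, with a range from 9000 nM to 55000 nM.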

Compound 4, half-maximal inhibitory concentration: > 100000 nM
Compound 4 gave a limit, no number; the forecaster's own chance of this, stated with the estimate: 10%; at least 4.5-fold (0.65 log units) between middle value and limit.
By their numbers in this assay, from the lowest: compounds 1, 2 and 3 (each within the scatter of the next). At a limit, above all of these: compound 4.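

In this assay compound 4 gives > 100000 nM, which is a limit of the assay and not a number. The earlier compounds shown here showed no aryl change on this amide-type nitrogen that moved the read-out beyond the scatter, but the 2-methoxyphenyl compound does so against all three of them: an at least 3.5-fold higher number from compound 3 to compound 4 (0.54 log units; beyond the scatter), an at least 5.5-fold higher number from compound 2 to compound 4 (0.74 log units; beyond the scatter) and an at least 6.4-fold higher number from compound 1 to compound 4 (0.80 log units; beyond the scatter). The group on this nitrogen therefore does matter to the read-out, although the contrast rests on a single compound at a limit: the limit of > 100000 nM in this assay, at which 1 of the 4 values shown sits.

The compounds shown leave open how large these steps really are and whether the methoxy group itself carries them, and they offer no reason for the change. They also leave open whether a hydroxy or an amino group in place of that methoxy on the aromatic carbon would give a number in line with compound 2 or a limit like that of compound 4.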